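The source may report more compounds than this note shows. Statements on the series, on what has been measured and on what is new or still open speak of the compounds shown alone.

In a functional assay on U-373MG ATCC cells (Homo sapiens) for inhibition, read by MTT assay, with a stated time of 72 h (on this read-out higher numbers stand for weaker inhibition and lower numbers for stronger inhibition), compound 1 `CC1(C)CC(NC(=S)NCc2ccccc2)c2cc(F)ccc2O1` gives 27000 nM, compound 2 `CC1(C)CC(NC(=S)Nc2ccc(C#N)cc2)c2cc(F)ccc2O1` gives 11000 nM and compound 3 `CC1(C)CC(NC(=S)Nc2cccc(C#N)c2)c2cc(F)ccc2O1` gives 30000 nM. Compound 2 holds the lowest of the three numbers, as shown by a 2.5-fold lower number from compound 1 to compound 2 (0.39 log units; beyond the scatter) and a 2.7-fold higher number from compound 2 to compound 3 (0.44 log units; beyond the scatter), while a 1.1-fold higher number from compound 1 to compound 3 (0.05 log units; within the scatter) stays within the scatter. Compound 4 `CC1(C)CC(NC(=S)Nc2ccc(C#N)cc2)c2cc(Br)ccc2O1` keeps the 4-cyanophenyl group of compound 2 and carries bromo in place of fluoro on an aromatic carbon. All measured steps concern the group on the amide-type nitrogen, so none tests this exchange directly. No step beyond the scatter is therefore expected in this assay, with a slightly lower number the likelier direction. The expected step is a 1.4-fold lower number from compound 2 to compound 4 (0.14 log units; within the scatter). For compound 4 the estimated value is 8000 nM, expected between 3000 nM and 20000 nM.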

Compound 4, half-maximal inhibitory concentration: 22000 nM
Beside the measured number, compound 4's estimate is 2.8-fold (0.44 log units) below it; measured number above the stated range.
By their numbers in this assay, from the lowest: compounds 2, 4, 1 and 3 (each within the scatter of the next, the first and the last beyond it).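

First direct test of the aromatic carbon carrying the halogen: in this assay, bromo in place of fluoro gives a 2.0-fold higher number from compound 2 to compound 4 (0.30 log units; within the scatter). With the 4-cyanophenyl group held constant, this exchange is therefore not separated from repeat-measurement noise, and compound 2 and compound 4 read as equivalent here. No available measurement bears on a reason for this result. Open, going by these compounds, is whether an amine or a methoxy group on this carbon would give a step beyond the scatter. Also open, on these data alone, is whether bromo reads the same alongside the benzyl group of compound 1.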